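The source may report more compounds than this note shows. Statements on the series, on what has been measured and on what is new or still open speak of the compounds shown alone.

Measured so far:
- compound 1, `Cc1ccc(S(=O)(=O)/N=C(/CCNC2=CC(=O)c3ccccc3C2=O)Nc2ccccc2I)cc1`: 24700 nM
- compound 2, `Cc1ccc(S(=O)(=O)/N=C(/CCNC2=CC(=O)c3ccccc3C2=O)Nc2cccc(C)c2)cc1`: 18700 nM
- compound 3, `Cc1ccc(S(=O)(=O)/N=C(/CCNC2=CC(=O)c3ccccc3C2=O)Nc2ccc(Cl)cc2Cl)cc1`: 32900 nM

All three numbers come from a functional assay on A549 cells (Homo sapiens) for cytotoxicity, read by MTT assay, with a stated time of 48 h; a higher number here means a weaker inhibitor, a lower number a stronger inhibitor. The three sit close together: a 1.3-fold lower number from compound 1 to compound 2 (0.12 log units; within the scatter) and a 1.8-fold higher number from compound 2 to compound 3 (0.25 log units; within the scatter) are both within the scatter, as is a 1.3-fold higher number from compound 1 to compound 3 (0.12 log units; within the scatter), so compound 2 cannot be set apart from compound 1 or compound 3 on these numbers.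

Compound 4, `Cc1ccc(S(=O)(=O)/N=C(/CCNC2=CC(=O)c3ccccc3C2=O)NCc2ccccc2)cc1`, is not yet measured. Its change from compound 2: benzyl in place of 3-methylphenyl on an amine nitrogen. Going by the values given here, none of the measured steps makes this kind of change; each of them swaps one substituted phenyl for another on the same amine nitrogen, and each stays within the scatter. Among the compounds with values here, nothing measured here speaks to a benzyl group at this position, so the expectation rests only on the flatness of the three known numbers and carries a wide range.

Compound 4 is expected in this assay at 20000 nM, with a range from 7000 nM to 60000 nM. The expected step from compound 2 is a 1.1-fold higher number from compound 2 to compound 4 (0.03 log units; within the scatter), that is, no step beyond the scatter is expected.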

Compound 4, half-maximal inhibitory concentration: 7410 nM
Compound 4: the middle estimate sits 2.7-fold (0.43 log units) above what was measured; the range from low to high includes it.
By their numbers in this assay, from the lowest: compound 4; then compounds 2, 1 and 3 (each within the scatter of the next).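

In this assay, the amine nitrogen is now shown to respond to a change beyond the scatter, which none of the swaps among substituted phenyl groups did: benzyl gives a 2.5-fold lower number from compound 2 to compound 4 (0.40 log units; beyond the scatter), and against the other two phenyl groups it gives a 3.3-fold lower number from compound 1 to compound 4 (0.52 log units; beyond the scatter) and a 4.4-fold lower number from compound 3 to compound 4 (0.65 log units; beyond the scatter). In the step from 3-methylphenyl to benzyl, the leaving and entering groups have the same heavy-atom count and one aromatic ring each, so the same atoms joined differently are enough to move the number. Nothing available explains this shift.

On these data alone, the benzyl finding rests on compound 4 alone, so it remains open whether a chlorobenzyl group would keep the step. As far as these compounds go, it is also open whether a phenylethyl chain would extend it or a plain cyclohexylmethyl group would retain it.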